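Fluoro in place of methoxy in a weakly active sulfonyl hydrazide

The source may hold more compounds than are shown below. What is called first, only, known or untested is meant among the compounds shown, and "the series" means these compounds.

Compound 3 `COc1ccc(NNS(=O)(=O)c2ccc(NC(C)=O)cc2)cc1` is known in an assay on HeLa cells for inhibition of Indoleamine 2,3-dioxygenase 1 (Homo sapiens), read by spectrophotometry, with a stated time of 24 h (a lower number here means that less compound is needed, a higher number that more compound is needed for the effect), only as a limit, > 10000 nM. That result sits at the limit of > 10000 nM in this assay, at which 1 of the 3 values shown sits, so no number is available for it. Compound 4 `CC(=O)Nc1ccc(S(=O)(=O)NNc2ccc(F)cc2)cc1` differs from compound 3 by a single change, (fluoro in place of methoxy on an aromatic carbon). Among the measured compounds shown here, no measured step concerns an exchange of this kind. Compound 1 `Cc1cccc(NNS(=O)(=O)c2ccc(C(=O)NCC(=O)O)cc2)c1` gives 271 nM and compound 2 `Cc1cccc(NNS(=O)(=O)c2ccc(S(C)(=O)=O)cc2)c1` gives 7850 nM; the step of a 29-fold higher number from compound 1 to compound 2 (1.46 log units; beyond the scatter) alters a group on the other aromatic ring and does not bear on the present exchange. With compound 3 known only as a limit, no step beyond the scatter is expected in this assay in either direction. Compound 4 is therefore estimated at 9000 nM, with a range from 2500 nM to 30000 nM. The expected step is an at least 1.1-fold lower number from compound 3 to compound 4 (0.04 log units; that floor lies within the scatter).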

Compound 4, half-maximal effective concentration: 609 nM
The estimate for compound 4 lay 15-fold (1.17 log units) above the measured number, outside the stated range (below it).
By their numbers in this assay, from the lowest: compound 1; then compound 4; then compound 2. At a limit, above all of these: compound 3.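

In this assay, fluoro in place of methoxy on an aromatic carbon, para to a large group, gives an at least 16-fold lower number from compound 3 to compound 4 (1.21 log units; beyond the scatter). Among the compounds shown here, the earlier step changed a group on the other aromatic ring, so this is the first sign that a change at this place can also move the number by a large amount. The size of this step is only a floor, since compound 3 stands at a limit: the limit of > 10000 nM in this assay, at which 1 of the 4 values shown sits.

The compounds shown leave open whether the lower number comes with fluoro itself or with the loss of methoxy. As far as these compounds go, how hydrogen, chloro or an amine would read at this place also remains open.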